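This account rests on a few compounds, and the source may have more. Where it says the series, first, only, none or still open, it means among the compounds named here.

In an ADME assay on S9 fraction from liver (Rattus norvegicus) for metabolic stability, read by LC-MS, using NADPH, with a stated time of 30 min (on this read-out higher numbers stand for a more stable compound and lower numbers for a less stable compound), compound 1 `CCCCCCCCc1ccc(OCC(=O)Cn2ncnn2)cc1` gives < 5%, which is a limit of the assay and not a number. Going by the values given here, compound 2 `CCCCCCCCc1ccc(OCC(=O)Cn2nnnc2SC)cc1` gives 21%, the only actual number so far. Compound 3 `CCCCCCCCc1ccc(OCC(=O)Cn2nnnc2-c2ccccc2Cl)cc1` carries the next change, 2-chlorophenyl in place of methylsulfanyl on an aromatic carbon. Among the compounds with values here, one measured step bears on it, a number at least 16 percentage points higher from compound 1 to compound 2 (beyond the scatter), which is beyond the scatter and at least modest. That step brought in the methylsulfanyl group that now leaves, but it also changed the attachment to the chain, and its size is bounded by a limit at one end. It therefore gives no direction for the swap to 2-chlorophenyl. The expected change, a number 3 percentage points higher from compound 2 to compound 3 (within the scatter), lies within the scatter, though the uncertainty is wide in this assay. For compound 3 the estimated value is 24%, with an expected range of 7% to 50%.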

Compound 3, percent of the compound remaining: 42%
For compound 3 the middle estimate is 18 percentage points below the measured one; low and high end bracket the measured number.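

In this assay, the group on this aromatic carbon can shift the read-out by itself: 2-chlorophenyl in place of methylsulfanyl gives a number 21 percentage points higher from compound 2 to compound 3 (beyond the scatter). Unlike the earlier step, this one leaves the attachment to the chain unchanged and has a measured number at both ends, so its size can be read directly. The earlier step stays open-ended, as compound 1 carries a limit and not a number: the limit of < 5% in this assay, at which 1 of the 3 values shown sits.

As far as these compounds go, whether the gain follows the chlorine or the phenyl ring itself stays open, and plain phenyl or 2-methylphenyl on this carbon would separate the two. Which part of the structure of compound 3 sets its remaining read-out in this assay also stays open.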